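The source may report more compounds than this note shows. Statements on the series, on what has been measured and on what is new or still open speak of the compounds shown alone.

Compounds measured in an ADME assay on BaF3 cells (Mus musculus) for cytotoxicity, read by CellTiter-Glo and CCK-8 assay, with a stated time of 72 h; on this read-out higher numbers stand for weaker inhibition of growth and lower numbers for stronger inhibition of growth:
Compound 1 `CCC(=O)N(CCN(C)C)Cc1ccc(C(=O)Nc2ccc(C)c(Nc3nccc(-c4cccnc4)n3)c2)cc1`: > 10000 nM, a limit
Compound 2 `Cc1ccc(NC(=O)c2ccc(CN(CCN(C)C)C(=O)C(C)C)cc2)cc1Nc1nccc(-c2cccnc2)n1`: > 10000 nM, a limit

Compound 2 therefore has no number of its own, only a limit. Going by the values given here, the series so far offers (the limit of > 10000 nM in this assay, at which 2 of the 2 values shown sit). Compound 3 `CCCC(=O)N(CCN(C)C)Cc1ccc(C(=O)Nc2ccc(C)c(Nc3nccc(-c4cccnc4)n3)c2)cc1` has the same atoms as compound 2, joined differently: propyl in place of isopropyl on a carbonyl carbon. Among the compounds with values here, the one measured step that touches this part of the structure is a step that the two limits leave unreadable from compound 1 to compound 2, a methyl in place of hydrogen on a saturated chain carbon bound to the carbonyl carbon, and it gives no size to carry over. Compound 2 gives > 10000 nM, a limit, and on that ground no step beyond the scatter is expected in this assay, in either direction. The expected step is a step that the limit leaves unreadable from compound 2 to compound 3. For compound 3 the estimated value is 12000 nM, with an expected range from 6000 nM to 25000 nM.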

Compound 3, concentration for 50% growth inhibition: > 10000 nM
Compound 3: only a limit was reported (the forecaster's own chance of this, stated with the estimate: 85%); the middle value is on the limit's open side.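

No step can be read among compound 1, compound 2 and compound 3, because all three stop at the same limit: the limit of > 10000 nM in this assay, at which 3 of the 3 values shown sit.

The compounds shown leave open whether propyl and isopropyl on the carbonyl carbon differ at all in this assay, since no compound here has a value beyond that limit.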